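Swapping a Methoxy for a Methyl on Compound 2

The compounds below may be only part of what the source reports. "The series", "measured", "known", "first", "only" and "open" are said of these compounds alone.

Of the compounds shown here, three that share one core have been tested in a functional assay on SW-620 cells (Homo sapiens) for antiproliferative activity, read by MTT assay, with a stated time of 72 h; on this read-out higher numbers stand for weaker inhibition and lower numbers for stronger inhibition. Compound 1 `CC(C)(C)c1cn(C[C@H](O)[C@H]2OC(=O)C(OCc3ccccc3)=C2OCc2ccccc2)nn1` gives 35800 nM in this assay. Compound 3 `O=C1O[C@H]([C@@H](O)Cn2cc(-c3cc(F)cc(F)c3)nn2)C(OCc2ccccc2)=C1OCc1ccccc1` carries 3,5-difluorophenyl in place of tert-butyl on an aromatic carbon, and its value in this assay is not a number but a limit of the assay, > 100000 nM. That single measured step comes to an at least 2.7-fold higher number from compound 1 to compound 3 (0.44 log units; beyond the scatter). Compound 2 `COc1ccc(-c2cn(C/C=C3\OC(=O)C(OCc4ccccc4)=C3OCc3ccccc3)nn2)cc1` is likewise reported in this assay only as a limit, > 100000 nM. Compound 2 therefore sits at the limit of > 100000 nM in this assay, at which 2 of the 3 values shown sit, so no number is known for it.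

Compound 4 `Cc1ccc(-c2cn(C/C=C3\OC(=O)C(OCc4ccccc4)=C3OCc3ccccc3)nn2)cc1` is the untested partner of compound 2, and the change between them is methyl in place of methoxy on an aromatic carbon. Going by the values given here, no measured step concerns this swap: the only measured step, from compound 1 to compound 3, involves a different group, so nothing here says how a methyl compares with a methoxy. The starting point is that compound 2 already reaches the limit > 100000 nM. Compound 4 is therefore expected to show a step that the limit leaves unreadable from compound 2 to compound 4, meaning no movement beyond the scatter, and is estimated at 150000 nM with a range from 50000 nM to 500000 nM, most likely reported again only as a limit.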

Compound 4, half-maximal inhibitory concentration: > 100000 nM
Compound 4: only a limit was reported; the forecaster's own chance of this, stated with the estimate: 80%; the middle value lies beyond the limit too.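

In this assay compound 4 gives > 100000 nM, a limit of the assay and not a number. Compound 2 is also reported only as a limit, so no step can be read between compound 2 and compound 4: the limit of > 100000 nM in this assay, at which 3 of the 4 values shown sit.

The compounds shown leave open how 4-methoxyphenyl and 4-methylphenyl truly compare in this assay.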